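The source may report more compounds than this note shows. Statements on the series, on what has been measured and on what is new or still open speak of the compounds shown alone.

Compound 3, `Cc1cc(-c2ncnc3c2ncn3C2O[C@H](CO)[C@@H](O)[C@H]2O)on1`, carries a 3-methyl-1,2-oxazol-5-yl group on the shared core, and in a functional assay on CCRF-CEM cells (Homo sapiens) for inhibition (on this read-out higher numbers stand for weaker inhibition and lower numbers for stronger inhibition), compound 3 is reported as "not active" (no number reported), with no number attached; it therefore has no single value to anchor a comparison. Compound 4, `Cc1ccsc1-c1ncnc2c1ncn2C1O[C@H](CO)[C@@H](O)[C@H]1O`, differs from it in one place: 3-methylthiophen-2-yl in place of 3-methyl-1,2-oxazol-5-yl on an aromatic carbon. Within the data shown here, the only measured step that speaks to a swap of this five-membered ring is the one between compound 1, `OC[C@H]1OC(n2cnc3c(-c4ccco4)ncnc32)[C@H](O)[C@@H]1O`, which gives 600 nM in this assay, and compound 2, `Cc1csc(-c2ncnc3c2ncn3C2O[C@H](CO)[C@@H](O)[C@H]2O)n1`, which gives 6000 nM in this assay; that step, a 10-fold higher number from compound 1 to compound 2 (1.00 log units; beyond the scatter), shows that exchanging one five-membered aromatic ring for another at this position can move the read-out well beyond the scatter. The 3-methylthiophen-2-yl group of compound 4 shares with the furan-2-yl group of compound 1 a single ring hetero atom, whereas the rings of compound 2 and compound 3 each hold two. On that basis compound 4 is expected to recover measurable inhibition in this assay, landing between the values of compound 1 and compound 2 rather than at the inactive end where compound 3 sits. The estimate for compound 4 in this assay is 2500 nM, with a range from 500 nM to 15000 nM.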

Compound 4, half-maximal inhibitory concentration: 2500 nM
The estimate for compound 4 equals the measured number at the digits printed, within the range that was stated.
By their numbers in this assay, from the lowest: compound 1; then compound 4; then compound 2.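

In this assay the position tolerates a 3-methylthiophen-2-yl group: the exchange for 4-methyl-1,3-thiazol-2-yl gives a 2.4-fold lower number from compound 2 to compound 4 (0.38 log units; beyond the scatter) and shows that a methyl-bearing five-membered ring here can keep a measurable read-out. The exchange for furan-2-yl gives a 4.2-fold higher number from compound 1 to compound 4 (0.62 log units; beyond the scatter) and places the new group in the middle of the three numbered compounds, so rings with one hetero atom do not read alike, even though both compound 1 and compound 4 stand lower than compound 2, whose ring holds two. The step from compound 3 to compound 4 cannot be read, as compound 3 has no number, and nothing measured here accounts for any of these differences.

The compounds shown leave open whether the methyl group or the ring hetero atoms set the read-out, as no pair separates the two, and an unsubstituted thiophen-2-yl would bear on that question. They also leave open how an amine, a carboxylic acid or a longer alkyl chain would read on this aromatic carbon in place of a five-membered ring.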